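Methyl for methoxy on the distal phenyl ring

A few compounds are considered here, and "the series" means these few. Any claim that something is new, unique, unknown or untested is made for them only; others in the source may bear on it.

Measured so far:
Compound 1 `COC(=O)/C=C/c1cccc(N(Cc2ccc(/C=C/c3c(F)cccc3F)cc2)C(=O)C(C)C)c1`: 108 nM
Compound 2 `COC(=O)/C=C/c1cccc(N(Cc2ccc(-c3ccc(OC)cc3)cc2)C(=O)C(C)C)c1`: 97 nM

Both compounds were run in an assay on isolated protein with Bile acid receptor (Homo sapiens) as the target; on this read-out higher numbers stand for an effect only at larger amounts of compound and lower numbers for an effect already at smaller amounts. On this read-out compound 2 holds the lowest of the two numbers, with compound 1 nearest at a 1.1-fold lower number from compound 1 to compound 2 (0.05 log units; within the scatter), so the two sit within the scatter of each other and no order between them is claimed.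

Compound 3 `COC(=O)/C=C/c1cccc(N(Cc2ccc(-c3ccc(C)cc3)cc2)C(=O)C(C)C)c1` differs from compound 2 by methyl in place of methoxy on an aromatic carbon. Within the data shown here, the only measured step, the exchange of the whole substituent on that aromatic carbon going from compound 1 to compound 2, gave a 1.1-fold lower number from compound 1 to compound 2 (0.05 log units; within the scatter); a smaller trimming of the same group is taken as a weaker test of the same position. No step beyond the scatter is therefore expected in this assay, in either direction.

Compound 3 is estimated at 100 nM, between 50 nM and 200 nM, which corresponds to an expected step of a 1.0-fold higher number from compound 2 to compound 3 (0.01 log units; within the scatter).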

Compound 3, half-maximal effective concentration: 118 nM
Estimate against measurement, compound 3: 1.2-fold (0.07 log units) below, within the range that was stated.
By their numbers in this assay, from the lowest: compounds 2, 1 and 3 (each within the scatter of the next).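

In this assay, the change from 4-methoxyphenyl to 4-methylphenyl gives (a 1.2-fold higher number from compound 2 to compound 3 (0.09 log units; within the scatter)), so removing the oxygen and its hydrogen-bond acceptor from this place, para to a large group, does not move the number beyond the scatter. The wider exchange gives (a 1.1-fold higher number from compound 1 to compound 3 (0.04 log units; within the scatter)), which places 2-(2,6-difluorophenyl)ethenyl, 4-methoxyphenyl and 4-methylphenyl within the scatter of one another on the shared core. Across these three compounds, neither the small exchange nor the large ones separate the groups at this position. No evidence on the cause of these results is available.

Open, on these data alone, is whether an amine or a carboxylic acid in place of the methyl would give a step beyond the scatter. As far as these compounds go, a plain hydrogen or a longer chain such as butyl at the same place also remains untested against these three groups.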